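The source may hold more compounds than are shown below. What is called first, only, known or untested is meant among the compounds shown, and "the series" means these compounds.

The three compounds measured share a core and differ in the group attached to its amide-type nitrogen. Compound 1 `CC(=O)Oc1cccc(/C=C/C(=O)Nc2ccc3c(c2)COC3=O)c1` gives 30 nM in a functional assay on cells (T-cell, Mus musculus) for inhibition; on this read-out higher numbers stand for weaker inhibition and lower numbers for stronger inhibition. Compound 2 `CC(=O)Oc1ccc(/C=C/C(=O)Nc2ccc3c(c2)COC3=O)cc1OC(C)=O` gives 180 nM, and the step of a 6.0-fold higher number from compound 1 to compound 2 (0.78 log units; beyond the scatter) shows what acetoxy in place of hydrogen on an aromatic carbon did. Compound 3 `Cc1ccc(NC(=O)Nc2ccc3c(c2)COC3=O)cc1`, a urea rather than a cinnamamide, gives 2670 nM, the highest number of the three, with compound 2 nearest and compound 1 furthest from it.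

Compound 4 `O=C(Nc1ccc2c(c1)COC2=O)NC1CCCCC1` keeps the urea of compound 3 and changes only its substituent: cyclohexyl in place of 4-methylphenyl on an amide-type nitrogen. Within the data shown here, no measured step bears on this change. Among the measured compounds shown here, the only step, between compound 1 and compound 2, concerns acetoxy in place of hydrogen on an aromatic carbon and says nothing about a saturated ring in place of an aromatic one on a urea nitrogen. The estimate for compound 4 therefore stays close to compound 3, with wide bounds, and the expected step is a 1.1-fold higher number from compound 3 to compound 4 (0.05 log units; within the scatter). Compound 4 is expected to give about 3000 nM in this assay, between 600 nM and 15000 nM.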

Compound 4, half-maximal inhibitory concentration: 12700 nM
Compound 4: the middle estimate sits 4.2-fold (0.63 log units) below what was measured; measured number inside the range.
By their numbers in this assay, from the lowest: compound 1; then compound 2; then compound 3; then compound 4.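

On the urea, cyclohexyl in place of 4-methylphenyl gives a 4.8-fold higher number from compound 3 to compound 4 (0.68 log units; beyond the scatter) in this assay, the first step shown at this amide-type nitrogen. It shows that this position responds to the nature of the ring: two six-membered rings of carbon only, neither with a net charge, are not interchangeable here, and in this pair the aromatic ring goes with the stronger inhibition. Nothing available explains why the saturated ring gives the higher number.

The compounds shown leave open how an open hexyl chain, or a phenyl ring carrying an amine or a carboxylic acid in place of the methyl group, would read on this urea. They also leave open whether cyclohexyl in place of the aromatic ring would have a similar effect on the cinnamamide of compound 1.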